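Fluoro for hydrogen on the aryl hydrazone series

This account rests on a few compounds, and the source may have more. Where it says the series, first, only, none or still open, it means among the compounds named here.

Working notes on a small set of aryl hydrazone acetyl compounds tested in an assay on isolated protein for binding affinity to corticotropin-releasing factor receptor 1 (Homo sapiens); on this read-out lower numbers stand for stronger inhibition and higher numbers for weaker inhibition. Compound 1 `CC(=O)/C(=N\Nc1ccccc1C#N)Nc1cccc(Cl)c1` gives 415 nM; 415 nM (2 entries). Compound 2 `CC(=O)/C(=N\c1cccc(Cl)c1)NNc1ccc(Br)cc1` gives 1460 nM. Compound 3 `CC(=O)/C(=N\c1ccccc1)NNc1ccccc1C` gives 526 nM, the lower of the two numbers it is set against, with compound 2 standing higher by a margin beyond the usual scatter; compound 1 sits alongside as a further entry. For the measured compounds named here, no step between two measured compounds that differ in one place is available. Compound 4 `CC(=O)/C(=N\c1cccc(F)c1)NNc1ccccc1C` differs from compound 3 by fluoro in place of hydrogen on an aromatic carbon, a fluoro in place of hydrogen on an aromatic carbon, meta to a large group. Such a change is expected to give a step of a 1.1-fold lower number from compound 3 to compound 4 (0.02 log units; within the scatter) in this assay, not beyond the scatter in either direction. Compound 4 is therefore estimated at 500 nM, within 200 nM to 1300 nM.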

Compound 4, inhibition constant: 43 nM
Beside the measured number, compound 4's estimate is 12-fold (1.07 log units) above it, and the stated range ends above it.
By their numbers in this assay, from the lowest: compound 4; then compound 3; then compound 2.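

In this assay, fluoro in place of hydrogen on an aromatic carbon, meta to a large group, gives a 12-fold lower number from compound 3 to compound 4 (1.09 log units; beyond the scatter), a large step and the first one in the series that can be read at a single place. The earlier compounds shown here could not show that this position responds so strongly to a single fluorine atom. Nothing measured here accounts for the size of this step. Open, from the compounds shown here alone, is whether a methoxy group or an amine in the same place would give a comparable step, and whether fluoro elsewhere on that ring would do so.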